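From 3-fluorophenyl to 3-nitrophenyl: an antiproliferative estimate

The compounds below may be only part of what the source reports. "The series", "measured", "known", "first", "only" and "open" are said of these compounds alone.

Compounds measured in a functional assay on MCF7 cells (Homo sapiens) for antiproliferative activity, read by MTT assay, with a stated time of 48 h; on this read-out lower numbers stand for stronger inhibition and higher numbers for weaker inhibition:
- Compound 1 `COC(=O)/C(=C/c1ccccc1)CN1C(=O)[C@@H](OC)[C@H]1c1ccc(F)cc1`: 15600 nM
- Compound 2 `COC(=O)/C(=C/c1ccccc1)CN1C(=O)[C@@H](OC)[C@H]1c1ccc(Cl)cc1Cl`: no result reported
- Compound 3 `COC(=O)/C(=C/c1ccccc1)CN1C(=O)[C@@H](OC)[C@H]1c1cccc(F)c1`: 13700 nM

Going by the values given here, only two numbers are available in this assay, and compound 3 at 13700 nM cannot be separated from compound 1 at 15600 nM. The step between them is a 1.1-fold lower number from compound 1 to compound 3 (0.06 log units; within the scatter), which places 3-fluorophenyl where 4-fluorophenyl stood. Compound 2 adds no number to the comparison.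

The next compound is compound 4 `COC(=O)/C(=C/c1ccccc1)CN1C(=O)[C@@H](OC)[C@H]1c1cccc([N+](=O)[O-])c1`, which keeps the shared core and has nitro in place of fluoro on an aromatic carbon. The group sits on the same carbon as the fluoro of compound 3, meta to a large group.

Among the compounds with values here, no measured step exchanges fluoro for another group, so the data give no direct measure of this change. Within the data shown here, the one step available, a 1.1-fold lower number from compound 1 to compound 3 (0.06 log units; within the scatter), shows only that the position of the fluoro made no difference beyond the scatter. No clear shift in either direction is therefore expected, although the uncertainty is wide. The estimated step is a 1.1-fold lower number from compound 3 to compound 4 (0.06 log units; within the scatter). For compound 4 the expected value is 12000 nM, with an estimated range from 4500 nM to 32000 nM.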

Compound 4, half-maximal inhibitory concentration: 15000 nM
Estimate against measurement, compound 4: 1.3-fold (0.10 log units) below; the range from low to high includes it.
By their numbers in this assay, from the lowest: compounds 3, 4 and 1 (each within the scatter of the next).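

In this assay, going by these compounds alone, the earlier compounds showed only that moving a fluoro group made no difference beyond the scatter; compound 4 is the first case here in which the fluoro itself is exchanged, on an aromatic carbon of the six-membered ring. That exchange gives a 1.1-fold higher number from compound 3 to compound 4 (0.04 log units; within the scatter), so nitro, with its three heavy atoms and two hydrogen-bond acceptors, stands where a single fluorine stood without a change that can be told from the scatter, and the comparison with the 4-fluorophenyl compound, a 1.0-fold lower number from compound 1 to compound 4 (0.02 log units; within the scatter), is just as flat, leaving compounds 1, 3 and 4 indistinguishable in this read-out. Nothing measured here accounts for this flat result.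

Within the data shown here, whether an amine or a carboxylic acid on this same aromatic carbon would carry the number beyond the scatter remains open, since fluoro and nitro are the only two groups compared there. Also open, as far as these compounds go, is whether a longer chain or a methoxy group in this place would behave as these two do, or whether any change at this carbon can move the number at all.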